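Moving the Chlorine Around the Benzamide Ring

The compounds below may be only part of what the source reports. "The series", "measured", "known", "first", "only" and "open" are said of these compounds alone.

Two analogues sharing one core have been tested in a functional assay on MDA-MB-231 cells (Homo sapiens) for antiproliferative activity, read by MTT assay, with stated times of 72 h and 4 h; a lower number here means a stronger inhibitor, a higher number a weaker inhibitor. Compound 1 `O=C(Nc1ccc(Cl)c(-c2nnc3c(Cl)cccn23)c1)c1ccc(C(F)(F)F)cc1Cl` carries both a trifluoromethyl group and a chlorine on its benzamide ring. For compound 1 this assay reports only a limit of > 100000 nM, not a number. Among the measured compounds shown here, compound 2 `O=C(Nc1ccc(Cl)c(-c2nnc3c(Cl)cccn23)c1)c1cccc(Cl)c1`, with a 3-chlorophenyl on the carbonyl carbon, gives 66100 nM in this assay, the only measured number here. The other result, that of compound 1, is the limit (the limit of > 100000 nM in this assay, at which 1 of the 2 values shown sits). Compound 3 `O=C(Nc1ccc(Cl)c(-c2nnc3c(Cl)cccn23)c1)c1ccccc1Cl` differs from compound 2 in one place: 2-chlorophenyl in place of 3-chlorophenyl on a carbonyl carbon. For the measured compounds named here, no comparable step between measured compounds exists, so there is no basis for expecting a shift in this assay beyond the usual scatter. The step of a 1.1-fold lower number from compound 2 to compound 3 (0.04 log units; within the scatter) is therefore expected to be small, in either direction. Compound 3 is estimated at 60000 nM, with a range from 20000 nM to 150000 nM.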

Compound 3, half-maximal inhibitory concentration: 59900 nM
The estimate for compound 3 lay 1.0-fold (0.00 log units) above the measured number; the measured number falls inside the stated range.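

Putting 2-chlorophenyl in place of 3-chlorophenyl on the carbonyl carbon gives a 1.1-fold lower number from compound 2 to compound 3 (0.04 log units; within the scatter) in this assay, so these two placings of the chlorine cannot be told apart in this test. Compound 1 stands at a limit, not a number: the limit of > 100000 nM in this assay, at which 1 of the 3 values shown sits.
Hydrogen in place of trifluoromethyl on an aromatic carbon gives an at least 1.6-fold lower number from compound 1 to compound 3 (0.22 log units; that floor lies within the scatter), a step that has only a floor, so its true size cannot be read.

It remains open whether any change on this benzamide ring can shift the number beyond the scatter, since neither step shown does so. An amine or a carboxylic acid in place of the chlorine would be a different kind of group at this spot, and the compounds shown say nothing about either.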